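Trimming cyclohexylmethyl to cyclohexyl on a carbonyl carbon

The source may hold more compounds than are shown below. What is called first, only, known or untested is meant among the compounds shown, and "the series" means these compounds.

Measured so far in an in vivo functional assay on the whole organism (MDA-MB-435 cells, Homo sapiens) for antiproliferative activity; on this read-out lower numbers stand for stronger inhibition and higher numbers for weaker inhibition:
- compound 1 `CO[C@@H](C(=O)NC1CC[C@@H](OC(=O)Cc2cccnc2)CNC1=O)[C@H](O)[C@@H](O)[C@H](O)/C=C/C(C)(C)C` gives 5850 nM
- compound 2 `CO[C@@H](C(=O)NC1CC[C@@H](OC(=O)CC2CCCCC2)CNC1=O)[C@H](O)[C@@H](O)[C@H](O)/C=C/C(C)(C)C` gives 60 nM

Compound 2 holds the lower of these two numbers. Within the data shown here, the one measured step is a 98-fold lower number from compound 1 to compound 2 (1.99 log units; beyond the scatter) and it puts cyclohexyl in place of pyridin-3-yl on a saturated chain carbon bound to a carbonyl carbon.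

The next compound is compound 3 `CO[C@@H](C(=O)NC1CC[C@@H](OC(=O)C2CCCCC2)CNC1=O)[C@H](O)[C@@H](O)[C@H](O)/C=C/C(C)(C)C` and its change from compound 2 is cyclohexyl in place of cyclohexylmethyl on a carbonyl carbon with the ring itself kept. The large measured step swapped one ring for another, so it bears on this change only loosely and gives no direction of its own. Among the measured compounds shown here, no measured step shows what removing the chain carbon does, which leaves the expectation uncertain. A modest move towards a higher number seems the likeliest outcome in this assay and it is expected to be a 2.0-fold higher number from compound 2 to compound 3 (0.30 log units; within the scatter) at this stage. For compound 3 the estimated value is 120 nM (expected range 30 nM to 600 nM).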

Compound 3, half-maximal inhibitory concentration: 4 nM
Compound 3: middle estimate off by 30-fold (1.48 log units), on the high side, outside the stated range (below it).
By their numbers in this assay, from the lowest: compound 3; then compound 2; then compound 1.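

In this assay, removing only the chain carbon and keeping the cyclohexane ring gives a 15-fold lower number from compound 2 to compound 3 (1.18 log units; beyond the scatter), so at this spot on the carbonyl carbon the link to the ring matters a great deal, and not only the identity of the ring, which was all the earlier step had tested. Taking both changes at once, from (pyridin-3-yl)methyl to cyclohexyl, gives a 1500-fold lower number from compound 1 to compound 3 (3.17 log units; beyond the scatter), a step that joins the two ends of this small series and leaves the ring attached directly to the carbonyl carbon with the lowest number of the three compounds. No supporting measurement is available to explain why this one small trim has such a large effect.

The compounds shown leave open whether the shorter link helps any ring or only cyclohexyl, and a phenyl or pyridin-3-yl ring placed directly on the carbonyl carbon would test this. They also leave open whether a smaller ring such as cyclopentyl, an open group such as tert-butyl, or a longer chain such as cyclohexylethyl would continue the same trend or break it.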